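From 2-methylphenyl to 2-chlorophenyl on the shared core

The source may report more compounds than this note shows. Statements on the series, on what has been measured and on what is new or still open speak of the compounds shown alone.

Values in a functional assay on K562 cells (Homo sapiens) for antiproliferative activity, with a stated time of 72 h; on this read-out lower numbers stand for stronger inhibition and higher numbers for weaker inhibition:
Compound 1 `Nc1ncnn2c([C@@H]3O[C@H](CO)[C@@H](O)[C@H]3O)cc(C#CC3CC3)c12` gives 40 nM
Compound 2 `Nc1ncnn2c([C@@H]3O[C@H](CO)[C@@H](O)[C@H]3O)cc(-c3ccccc3)c12` gives > 100000 nM (a limit)
Compound 3 `Cc1ccccc1-c1cc([C@@H]2O[C@H](CO)[C@@H](O)[C@H]2O)n2ncnc(N)c12` gives > 100000 nM (a limit)

Compound 3 sits on (the limit of > 100000 nM in this assay, at which 2 of the 3 values shown sit), and this is only a limit, not a number. Compound 4 `Nc1ncnn2c([C@@H]3O[C@H](CO)[C@@H](O)[C@H]3O)cc(-c3ccccc3Cl)c12` differs from it by chloro in place of methyl on an aromatic carbon. Two measured changes bear on this, both large: an at least 2500-fold higher number from compound 1 to compound 2 (3.39 log units; beyond the scatter) and an at least 2500-fold higher number from compound 1 to compound 3 (3.39 log units; beyond the scatter). The closest one, a step that the two limits leave unreadable from compound 2 to compound 3, cannot be sized. Compound 2 and compound 3 both keep a phenyl ring and both end at the limit, so no step beyond the scatter is expected in this assay. The expected change is a number no higher from compound 3 to compound 4 (the limit leaves the size open). Compound 4 is estimated at 100000 nM (range 20000 nM to 100000 nM), most likely again as a limit.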

Compound 4, half-maximal inhibitory concentration: > 100000 nM
Compound 4: a limit, no number (the forecaster's own chance of this, stated with the estimate: 80%); the middle value lies on the limit itself.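

In this assay compound 4 gives > 100000 nM, which is a limit and not a number. A chloro group at this place on the phenyl ring therefore brings no measurable value, any more than methyl or hydrogen did, and the steps among compound 2, compound 3 and compound 4 cannot be read. Against the 2-cyclopropylethynyl group, 2-chlorophenyl gives an at least 2500-fold higher number from compound 1 to compound 4 (3.39 log units; beyond the scatter), so a third phenyl compound now stands at the ceiling: the limit of > 100000 nM in this assay, at which 3 of the 4 values shown sit.

Going by these compounds, how the three phenyl compounds differ from one another stays open. So does whether an amine on that phenyl ring, or a longer chain on the alkyne of compound 1, would give a readable number.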